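The source may hold more compounds than are shown below. What is called first, only, known or untested is meant among the compounds shown, and "the series" means these compounds.

Measured so far in an ADME assay on L6 cells (Rattus norvegicus) for cytotoxicity, with a stated time of 72 h; a lower number here means a stronger inhibitor, a higher number a weaker inhibitor
Compound 1 `CN(C)C12CC(OC(=O)/C=C/c3ccccc3)C(C(c3ccccc3)C1)C(c1ccccc1)C2` gives 3820 nM
Compound 2 `O=C(/C=C/c1ccccc1)OC1CC2(N3CCCC3)CC(c3ccccc3)C1C(c1ccccc1)C2` gives 3500 nM

Going by the values given here, compound 2 stands level with compound 1, the only other measured compound, and the two values lie within the scatter (a 1.1-fold lower number from compound 1 to compound 2 (0.04 log units; within the scatter)). In compound 3 `O=C(CN1CCCCC1)OC1CC2(N3CCCC3)CC(c3ccccc3)C1C(c1ccccc1)C2` the pyrrolidin-1-yl group stays and the change falls elsewhere: (piperidin-1-yl)methyl in place of 2-phenylethenyl on a carbonyl carbon. Among the compounds with values here, the one measured step, pyrrolidin-1-yl in place of dimethylamino, concerns a different place and stayed within the scatter. Within the data shown here, no measured compound varies the group on the carbonyl carbon, so the data give no size for this change. The expectation therefore rests on the extent of the swap alone, which removes an aromatic ring, and it is a judgement with wide uncertainty. Starting from compound 2 at 3500 nM a higher number in this assay is expected, by a step beyond the scatter (estimated as a 3.4-fold higher number from compound 2 to compound 3 (0.54 log units; beyond the scatter)). For compound 3 the estimated value is about 12000 nM (expected range 4000 nM to 40000 nM).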

Compound 3, half-maximal inhibitory concentration: 14200 nM
For compound 3 the middle estimate is 1.2-fold (0.07 log units) below the measured one, and the stated range covers the measured number.
By their numbers in this assay, from the lowest: compounds 2 and 1 (each within the scatter of the next); then compound 3.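

The group on the carbonyl carbon, which compound 1 and compound 2 share, proves able to shift the number in this assay: (piperidin-1-yl)methyl in place of 2-phenylethenyl gives (a 4.1-fold higher number from compound 2 to compound 3 (0.61 log units; beyond the scatter)). This is the only step shown that lies beyond the scatter, whereas pyrrolidin-1-yl in place of dimethylamino stayed within it (a 1.1-fold lower number from compound 1 to compound 2 (0.04 log units; within the scatter)), so a measurable change in this assay has so far appeared only at this carbonyl position. The swap removes the aromatic ring and the double bond and brings in a non-aromatic six-membered ring containing a nitrogen, all in one step, and nothing available here separates these differences or explains the result.

Going by these compounds, it remains open whether a 2-phenylethyl group, which would keep the aromatic ring without the double bond, or a (morpholin-4-yl)methyl group, which would keep a non-aromatic six-membered ring with an oxygen added, would read like compound 2 or like compound 3. On these data alone, it is also open whether the same swap on the carbonyl carbon would give a similar step with dimethylamino on the saturated ring carbon, as in compound 1.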